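Fluorine on the benzamide ring of a 5-lipoxygenase series

The source may report more compounds than this note shows. Statements on the series, on what has been measured and on what is new or still open speak of the compounds shown alone.

Measured compounds:
- compound 1, `Cc1nc(NC(=O)c2ccccc2)sc1C(=O)/C=C/c1ccccc1`: 73.5%
- compound 2, `Cc1nc(NC(=O)c2ccccc2)sc1C(=O)/C=C/c1ccc(F)cc1`: 98%
- compound 3, `Cc1nc(NC(=O)c2ccccc2)sc1C(=O)/C=C/c1ccc(N(C)C)cc1`: 88.2%

In an assay for inhibition of Polyunsaturated fatty acid 5-lipoxygenase (Homo sapiens), read by spectrophotometry, tested at 10 uM, in the presence of a further agent that is not named here (a lower number here means less inhibition, a higher number more inhibition at the concentration tested (going by the name of the read-out)), compound 1 gives 73.5%. One change, (fluoro in place of hydrogen on an aromatic carbon), produced a number 24.5 percentage points higher from compound 1 to compound 2 (beyond the scatter). Compound 3 differs from compound 1 by dimethylamino in place of hydrogen on an aromatic carbon, which produced a number 14.7 percentage points higher from compound 1 to compound 3 (beyond the scatter). Compound 2 and compound 3 differ by a number 9.8 percentage points lower from compound 2 to compound 3 (within the scatter), so no order between them can be stated.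

Compound 4, `Cc1nc(NC(=O)c2ccc(F)cc2)sc1C(=O)/C=C/c1ccc(N(C)C)cc1`, has not been measured. It differs from compound 3 by fluoro in place of hydrogen on an aromatic carbon. Among the compounds with values here, this is the same kind of change as the one from compound 1 to compound 2, but it is made on a different ring: read one bond further out, the earlier change was phenyl to 4-fluorophenyl, this one is benzoyl to (4-fluorophenyl)carbonyl. Because the earlier step was a number 24.5 percentage points higher from compound 1 to compound 2 (beyond the scatter), a rise is plausible, yet compound 3 already stands high and a single step on one other ring is thin evidence. Compound 4 is therefore expected at 92%, a step of a number 3.8 percentage points higher from compound 3 to compound 4 (within the scatter), within the range 80% to 100%.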

Compound 4, a percentage reported as inhibition, at one concentration (the size of the read-out at that concentration, not a potency): 70.2%
The estimate for compound 4 lay 21.8 percentage points above the measured number; the whole stated range lies above it.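

In this assay, putting fluoro in place of hydrogen on the benzoyl ring gave a number 18 percentage points lower from compound 3 to compound 4 (beyond the scatter), so the rise seen earlier did not carry over to this new setting. Set side by side, the two results for this swap point in opposite directions, and the gap between them is real rather than noise: the same change on two cores in this assay, a number 24.5 percentage points higher (beyond the scatter) from compound 1 to compound 2 and a number 18 percentage points lower (beyond the scatter) from compound 3 to compound 4, 42.5 percentage points apart, beyond the scatter of two such steps This does not show why the swap behaves differently, since the two cases differ in two ways at once: one changes phenyl to 4-fluorophenyl on a molecule without dimethylamino, and the other changes benzoyl to (4-fluorophenyl)carbonyl on a molecule with dimethylamino, and each case rests on a single pair.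

The compounds shown leave open whether fluoro on the benzoyl ring would lower the number in a molecule without the dimethylamino group. They also leave open how a chloro or methoxy group would read in place of that fluoro.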